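The compounds below may be only part of what the source reports. "The series", "measured", "known", "first", "only" and "open" are said of these compounds alone.

Compound 2 `COc1ccc(/C=C\C(=O)N2N=C(c3ccncc3)OC2c2c[nH]c3ccccc23)cc1` sits at a limit of an ADME assay on HeLa cells (Homo sapiens) for cytotoxicity, read by MTT assay, with a stated time of 72 h; on this read-out higher numbers stand for weaker inhibition of growth and lower numbers for stronger inhibition of growth: compound 2 gives > 30 ug/mL, a limit rather than a number. Compound 1 `O=C(/C=C\c1cccc(O)c1)N1N=C(c2ccncc2)OC1c1c[nH]c2ccccc12` also gives a limit, > 30 ug/mL. Among the compounds with values here, the one measured step, a step that the two limits leave unreadable from compound 1 to compound 2, is therefore unreadable, and the limit of > 30 ug/mL in this assay, at which 2 of the 2 values shown sit, is all the series shows. Compound 3 `O=C(/C=C\c1ccc(Cl)cc1)N1N=C(c2ccncc2)OC1c1c[nH]c2ccccc12` differs from compound 2 by chloro in place of methoxy on an aromatic carbon. With both neighbours at the limit, no step beyond the scatter is expected, and compound 3 is expected at the limit again as a step that the limit leaves unreadable from compound 2 to compound 3. Compound 3 is estimated at 35 ug/mL, within 18 ug/mL to 70 ug/mL.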

Compound 3, concentration for 50% growth inhibition: > 30 ug/mL
Compound 3: no number, only a limit; the forecaster's own chance of this, stated with the estimate: 75%; the middle value does not contradict the limit.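

In this assay, within the data shown here, compound 3 gives > 30 ug/mL, a limit, so no step from compound 1 or compound 2 to compound 3 can be read. The compounds shown leave open what actual growth-inhibiting concentration any of the three has.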